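Methoxy for Methyl on a Benzylamide Cytotoxicity Series

The compounds below may be only part of what the source reports. "The series", "measured", "known", "first", "only" and "open" are said of these compounds alone.

Compound 1 `Nc1ccccc1NC(=O)CCCCCN(CC(=O)NC1CCCCC1)C(=O)c1ccccc1` — 181000 nM
Compound 2 `Cc1ccc(CNC(=O)CN(CCCCCC(=O)Nc2ccccc2N)C(=O)c2cc(C)cc(C)c2)cc1` — 9800 nM
Compound 3 `Nc1ccccc1NC(=O)c1ccc(CN(CC(=O)NCc2ccccc2)C(=O)c2cccnc2)cc1` — 8900 nM

In a functional assay on A2780 cells (Homo sapiens) for cytotoxicity, read by MTT assay, with a stated time of 72 h (a lower number here means a stronger inhibitor, a higher number a weaker inhibitor), compound 2 gives 9800 nM, the second highest of the three numbers. Compound 3 lies within the scatter of it at 8900 nM, while compound 1 stands far higher at 181000 nM, beyond the scatter. Compound 4 `COc1ccc(CNC(=O)CN(CCCCCC(=O)Nc2ccccc2N)C(=O)c2cc(C)cc(C)c2)cc1` differs from compound 2 in one place: methoxy in place of methyl on an aromatic carbon. Within the data shown here, no pair of measured compounds shows a change of this kind, so the expectation rests on compound 2 alone. The step of a 1.1-fold lower number from compound 2 to compound 4 (0.04 log units; within the scatter) is expected to be small, with no direction that reaches beyond the scatter. Compound 4 is accordingly estimated at 9000 nM, within a range from 3500 nM to 25000 nM.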

Compound 4, half-maximal inhibitory concentration: 24600 nM
Beside the measured number, compound 4's estimate is 2.7-fold (0.44 log units) below it; the measured number falls inside the stated range.
By their numbers in this assay, from the lowest: compounds 3 and 2 (each within the scatter of the next); then compound 4; then compound 1.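

In this assay, among these compounds, the change from 4-methylbenzyl to 4-methoxybenzyl gives the first reading at this position: a 2.5-fold higher number from compound 2 to compound 4 (0.40 log units; beyond the scatter), a modest step. The position, on a ring para to a large group, therefore responds to this exchange, and the methoxy goes with the weaker number. Nothing measured here accounts for the step.

Going by these compounds, whether any other group at this position would move the number the same way remains open, since this single pair sets no trend. How a hydroxyl, a chlorine or an amine there would compare with the methyl of compound 2 is also unanswered.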